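The compounds below may be only part of what the source reports. "The series", "measured", "known", "first", "only" and "open" are said of these compounds alone.

Measured compounds:
- Compound 1, `COC(=O)c1cc(NCc2ccccc2[N+](=O)[O-])c2cn[nH]c2c1`: 47%
- Compound 2, `CC(C)n1ncc2c(NCc3ccccc3[N+](=O)[O-])cc(C(F)(F)F)cc21`: 13%

In an assay for inhibition of Indoleamine 2,3-dioxygenase 1 (Homo sapiens), with stated times of 10 min and 60 min, tested at 100 uM (a higher number here means a stronger effect of the compound at the concentration tested, a lower number a weaker effect), compound 1 gives 47%, and in this assay compound 2 gives 13%. For the measured compounds named here, of the two numbers at hand, compound 2 stands lowest; compound 1 is its only neighbour, and the gap between the two lies beyond the usual scatter. The two compounds differ in more than one place, so the gap is not tied to any single change.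

Compound 3, `O=[N+]([O-])c1ccccc1CNc1cc(C(F)(F)F)cc2[nH]ncc12`, has not yet been measured in this assay. It differs from compound 2 in one place: hydrogen in place of isopropyl on an aromatic nitrogen. Going by the values given here, the free aromatic nitrogen that results is also present in compound 1, the stronger of the two measured compounds, though compound 1 carries a methyl ester where compound 3 carries a trifluoromethyl group, so no measured pair isolates this change.

Given that compound 1 reads 47% with the free aromatic nitrogen, the account expects a step of a number 17 percentage points higher from compound 2 to compound 3 (beyond the scatter), a moderate rise that may or may not clear the scatter. Compound 3 is accordingly estimated at 30%, within a range from 10% to 55%.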

Compound 3, a percentage reported as inhibition, at one concentration (the size of the read-out at that concentration, not a potency): 76%
For compound 3 the middle estimate is 46 percentage points below the measured one, and the stated range ends below it.
By their numbers in this assay, from the lowest: compound 2; then compound 1; then compound 3.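

In this assay, for the compounds shown here, hydrogen in place of isopropyl on an aromatic nitrogen gives a number 63 percentage points higher from compound 2 to compound 3 (beyond the scatter), a large step, and this is the first measured pair to isolate that position, which the gap between the two earlier compounds could not do. Compound 3 also supplies a second single-place comparison: with hydrogen on that nitrogen in both compounds, trifluoromethyl in place of methoxycarbonyl on an aromatic carbon gives a number 29 percentage points higher from compound 1 to compound 3 (beyond the scatter), a modest step, so the trifluoromethyl group goes with the higher reading in this pair. Nothing available here explains why either step takes the size it does.

From the compounds shown here alone, with only hydrogen and isopropyl seen on this nitrogen, it remains open whether a methyl or an ethyl group there would read nearer to compound 3 or nearer to compound 2. Going by these compounds, it is also open how a nitrile or a chlorine atom would read in place of trifluoromethyl on the aromatic carbon, and whether the step at the nitrogen would keep its size with methoxycarbonyl on that carbon.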